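Changing the sulfonyl aryl group of compound 1

The source may hold more compounds than are shown below. What is called first, only, known or untested is meant among the compounds shown, and "the series" means these compounds.

In a functional assay on A2780 cells (Homo sapiens) for inhibition, read by sulforhodamine B assay, with a stated time of 72 h (a lower number here means a stronger inhibitor, a higher number a weaker inhibitor), compound 1 (`Cc1ccccc1S(=O)(=O)c1ccc(CNC(=O)c2cc3cnccc3[nH]2)cc1`) gives 13 nM, the lower of the two numeric values in this set. Compound 3 (`O=C(NCc1ccc(S(=O)(=O)N2CCCCC2)cc1)c1cc2cnccc2s1`) gives 1600 nM, a higher number well beyond the scatter. Compound 2 (`O=C(NCc1ccc(S(=O)(=O)c2ccccc2)cc1)c1cc2ncccc2s1`) reads > 10000 nM, which is a limit of the assay and not a number.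

Compound 4 (`O=C(NCc1ccc(S(=O)(=O)c2cccc(C(F)(F)F)c2)cc1)c1cc2cnccc2[nH]1`) carries 3-(trifluoromethyl)phenyl in place of 2-methylphenyl on a sulfonyl sulfur. For the measured compounds named here, no measured pair isolates this change. Compound 4 keeps the core of compound 1, which gives 13 nM, so only a small change in this assay is expected, with no clear direction beyond the scatter. The expected step is a 1.5-fold higher number from compound 1 to compound 4 (0.19 log units; within the scatter). For compound 4 the estimated value is 20 nM, with an expected range of 4 nM to 100 nM.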

Compound 4, half-maximal inhibitory concentration: 3 nM
Compound 4: middle estimate off by 6.7-fold (0.82 log units), on the high side; the measured number lies below the stated range.
By their numbers in this assay, from the lowest: compound 4; then compound 1; then compound 3. At a limit, above all of these: compound 2.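

On the sulfonyl sulfur, the aryl group still affects the number with the core of compound 1 held fixed: in this assay, 3-(trifluoromethyl)phenyl in place of 2-methylphenyl gives a 4.3-fold lower number from compound 1 to compound 4 (0.64 log units; beyond the scatter). The position therefore accepts the larger aryl group, with 10 heavy atoms against 7, without any loss of inhibition. Nothing shown gives a cause for this step.

For the compounds shown here, the one pair changes both the substituent and its place on the ring, so the two cannot be separated. From the compounds shown here alone, how a phenyl group carrying an amine or a carboxylic acid would read on this sulfur remains open.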